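The source may hold more compounds than are shown below. What is called first, only, known or untested is meant among the compounds shown, and "the series" means these compounds.

Measured in a functional assay on NCI-N87 cells (Homo sapiens) for inhibition, read by CellTiter-Glo, with a stated time of 72 h; a lower number here means a stronger inhibitor, a higher number a weaker inhibitor:

- Compound 1 `Cc1cc(Nc2ncnc3cc(O)c(NC(=O)/C=C/[C@H]4CCCN4C)cc23)ccc1Oc1ccn2ncnc2c1`: 2.65 nM
- Compound 2 `C=CC(=O)Nc1cc2c(Nc3ccc(Oc4cc5nncn5cn4)c(C)c3)ncnc2cc1OCC`: 51.9 nM
- Compound 3 `Cc1cc(Nc2ncnc3cc(O)c(NC(=O)/C=C/[C@H]4CCCN4C)cc23)ccc1Oc1cc2nccn2cn1`: 41.7 nM

Compound 3 lies within the scatter of compound 2, and both numbers are well above that of compound 1. The next compound, compound 4 `Cc1cc(Nc2ncnc3cc(O)c(NC(=O)/C=C/[C@H]4CCCN4C)cc23)ccc1Oc1ccc2nccn2c1`, changes the group on the oxygen of compound 3: a group of 9 heavy atoms (7 carbon, 2 nitrogen; one five-membered aromatic ring with 2 hetero atoms, one six-membered aromatic ring with 1 hetero atom) in place of a group of 9 heavy atoms (6 carbon, 3 nitrogen; one five-membered aromatic ring with 2 hetero atoms, one six-membered aromatic ring with 2 hetero atoms), on an oxygen on an aromatic ring. For the measured compounds named here, only one measured step bears on this change, at the same place: a 16-fold higher number from compound 1 to compound 3 (1.20 log units; beyond the scatter). That step is large, but it is a single observation. The incoming group of compound 4 has the six-membered aromatic ring with 1 hetero atom found in compound 1, and it keeps the five-membered aromatic ring with 2 hetero atoms found in compound 3. A partial return toward compound 1 in this assay is therefore expected, with a lower number but a smaller step than the measured one. The expected change is a 3.5-fold lower number from compound 3 to compound 4 (0.54 log units; beyond the scatter). The estimate for compound 4 is 12 nM, with an expected range from 3 nM to 45 nM.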

Compound 4, half-maximal inhibitory concentration: 4.08 nM
For compound 4 the middle estimate is 2.9-fold (0.47 log units) above the measured one; the range from low to high includes it.
By their numbers in this assay, from the lowest: compounds 1 and 4 (each within the scatter of the next); then compounds 3 and 2 (each within the scatter of the next).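

The change pays back almost all of the earlier loss: in this assay, there is a 10-fold lower number from compound 3 to compound 4 (1.01 log units; beyond the scatter), while there is only a 1.5-fold higher number from compound 1 to compound 4 (0.19 log units; within the scatter), and that step lies within the scatter. On this oxygen, then, the two groups with one six-membered aromatic ring with 1 hetero atom cannot be told apart, even though their five-membered rings differ, and compound 3, with one six-membered aromatic ring with 2 hetero atoms, is the one that stands apart among these three. The data give no measurement that explains these steps.

The compounds shown leave open how a group with no ring hetero atom, such as a plain phenyl, or a single pyridine ring would behave on this oxygen. They also leave open whether the same steps would hold on the core of compound 2, with its unsubstituted acrylamide and ethoxy group.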